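The compounds below may be only part of what the source reports. "The series", "measured", "known", "first", "only" and "open" are said of these compounds alone.

Measured compounds and half-lives in an ADME assay on microsomes from liver (Homo sapiens) for metabolic stability, using NADPH, with a stated time of 40 min, tested at 2 uM; a higher number here means that the compound lasts longer, a lower number that the compound disappears faster:

compound 1 `Cc1cccc2c(-c3ccc4c(O)cccc4n3)c[nH]c12`: 0.283 h
compound 2 `Clc1cccc2c(-c3ccc4ccccc4n3)c[nH]c12`: 0.283 h
compound 3 `Cc1cccc2c(-c3ccc4ccc(Cl)cc4n3)c[nH]c12`: 1.48 h

Compound 2 stands level with compound 1 at the digits shown; the two values lie within the usual scatter of each other. Compound 3 stands higher than compound 2, a gap beyond the scatter. Among the compounds with values here, no pair of measured compounds differs in one place, so no step of the kind seen between compound 2 and compound 4 has been measured.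

Compound 4 `Cc1cc(Cl)c2[nH]cc(-c3ccc4ccccc4n3)c2c1` is not yet measured. It differs from compound 2 as follows: methyl in place of hydrogen on an aromatic carbon

The measured compounds give no guide to this change. The step of a 1.2-fold higher number from compound 2 to compound 4 (0.09 log units; within the scatter) is expected to stay within the scatter, with no clear direction. Compound 4 is estimated at 0.35 h, in the range 0.15 h to 0.8 h.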

Compound 4, half-life: 0.3 h
Compound 4: the middle estimate sits 1.2-fold (0.07 log units) above what was measured; the range from low to high includes it.
By their numbers in this assay, from the lowest: compounds 1, 2 and 4 (each within the scatter of the next); then compound 3.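

In this assay, within the data shown here, methyl in place of hydrogen on an aromatic carbon, meta to a chloro group, gives a 1.1-fold higher number from compound 2 to compound 4 (0.03 log units; within the scatter) and is the only step here between compounds that differ in one place. At this position, a single added methyl therefore leaves the half-life within the scatter. Nothing available explains this result.

From the compounds shown here alone, whether an amine, a carboxylic acid or a longer chain at this position would shift the half-life remains open. So does whether methyl here behaves the same way when the chloro group is replaced.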